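This account rests on a few compounds, and the source may have more. Where it says the series, first, only, none or still open, it means among the compounds named here.

Measured compounds in an assay on cells (Endothelial cell) for binding affinity to Endothelin-1 receptor (Sus scrofa); on this read-out higher numbers stand for weaker inhibition and lower numbers for stronger inhibition:
- compound 1 `COCCOc1ncnc(NS(=O)(=O)c2ccc(C(C)(C)C)cc2)c1Oc1cccc(OC)c1`: 92 nM
- compound 2 `COc1cccc(Oc2c(NS(=O)(=O)c3ccc(C(C)(C)C)cc3)ncnc2OCCOCc2ccccc2)c1`: 170 nM
- compound 3 `COc1cccc(Oc2c(NS(=O)(=O)c3ccc(C(C)(C)C)cc3)ncnc2OCCOc2ncccn2)c1`: 1.9 nM

Compound 2 carries the highest number of the three. Compound 1 sits nearest, with a 1.8-fold higher number from compound 1 to compound 2 (0.27 log units; within the scatter); compound 3 sits furthest, with an 89-fold lower number from compound 2 to compound 3 (1.95 log units; beyond the scatter).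

Compound 4 `COc1cccc(Oc2c(NS(=O)(=O)c3ccc(C(C)(C)C)cc3)ncnc2OCCOc2ncc(C)cn2)c1` is not yet measured. It differs from compound 2 in one place: 5-methylpyrimidin-2-yl in place of benzyl on an oxygen on a saturated carbon.

For the measured compounds named here, two measured steps bear on this change. Replacing benzyl by pyrimidin-2-yl on an oxygen on a saturated carbon gave an 89-fold lower number from compound 2 to compound 3 (1.95 log units; beyond the scatter), and replacing methyl by pyrimidin-2-yl there gave a 48-fold lower number from compound 1 to compound 3 (1.69 log units; beyond the scatter); both are large and run the same way. Going by the values given here, the change to compound 4 differs from the step to compound 3 only by the methyl within the entering 5-methylpyrimidin-2-yl, and no measured pair isolates that methyl. Compound 4 is therefore expected to show a 68-fold lower number from compound 2 to compound 4 (1.83 log units; beyond the scatter) in this assay, a large move in the same direction. Compound 4 is estimated at 2.5 nM, within a range from 0.8 nM to 8 nM.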

Compound 4, half-maximal inhibitory concentration: 0.86 nM
Beside the measured number, compound 4's estimate is 2.9-fold (0.46 log units) above it; the measured number falls inside the stated range.
By their numbers in this assay, from the lowest: compound 4; then compound 3; then compounds 1 and 2 (each within the scatter of the next).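

In this assay the methyl on the aromatic carbon of the 5-methylpyrimidin-2-yl group is a separate, readable change: methyl in place of hydrogen gives a 2.2-fold lower number from compound 3 to compound 4 (0.34 log units; beyond the scatter) and is modest but beyond the scatter, so the pyrimidin-2-yl group on this oxygen accepts a substituent without losing the earlier gain. With that methyl in place, the large steps from the benzyl and methyl ethers persist, with a 200-fold lower number from compound 2 to compound 4 (2.30 log units; beyond the scatter) and a 110-fold lower number from compound 1 to compound 4 (2.03 log units; beyond the scatter) as the new extremes of the series. The data shown offer no measured explanation for these steps.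

Whether the step belongs to methyl in particular remains open, since ethyl, methoxy, chlorine or an amine on that carbon are not among the compounds shown. Also open, going by these compounds, is whether the large steps would survive a longer chain in place of the ethyl link to the oxygen.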